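Nitro for Ethoxy on a Rho Kinase Inhibitor

This account rests on a few compounds, and the source may have more. Where it says the series, first, only, none or still open, it means among the compounds named here.

Measured compounds:
- Compound 1, `CCc1ccc(C(=O)Nc2cccc(NC(=O)COc3ccc4c(=O)ccoc4c3)c2)cc1`: 235 nM
- Compound 2, `O=C(COc1ccc2c(=O)ccoc2c1)Nc1cccc(NC(=O)c2ccc(F)cc2)c1`: 129 nM
- Compound 3, `CCOc1ccc(C(=O)Nc2cccc(NC(=O)COc3ccc4c(=O)ccoc4c3)c2)cc1`: 17 nM

In an assay on isolated protein for inhibition of Rho-associated protein kinase 1 (Homo sapiens), read by scintillation counting, radiometric assay and 33P incorporation, with a stated time of 40 min, in the presence of a further agent that is not named here (a higher number here means a weaker inhibitor, a lower number a stronger inhibitor), compound 3 gives the lowest number of the three, the strongest inhibition shown here. The step of a 7.6-fold lower number from compound 2 to compound 3 (0.88 log units; beyond the scatter) lies beyond the scatter, and the step of a 14-fold lower number from compound 1 to compound 3 (1.14 log units; beyond the scatter) is larger still, so compound 3 stands clearly apart from both. Between compound 1 and compound 2 the step of a 1.8-fold lower number from compound 1 to compound 2 (0.26 log units; within the scatter) is within the scatter.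

Compound 4, `O=C(COc1ccc2c(=O)ccoc2c1)Nc1cccc(NC(=O)c2ccc([N+](=O)[O-])cc2)c1`, differs from compound 3 in one place: nitro in place of ethoxy on an aromatic carbon. Among the compounds with values here, no measured step swaps the ethoxy for a nitro, so the expectation rests on the pattern that the ethoxy alone gave the strong result, while fluoro and ethyl in the same place gave weaker ones. A nitro group is neither of those, so the direction is uncertain, but losing the ethoxy has so far cost potency in every measured step from compound 3. For compound 4 the expectation is therefore a step of a 5.9-fold higher number from compound 3 to compound 4 (0.77 log units; beyond the scatter), toward a higher number. Compound 4 is estimated at 100 nM, with a range from 30 nM to 350 nM.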

Compound 4, half-maximal inhibitory concentration: 67 nM
For compound 4 the middle estimate is 1.5-fold (0.17 log units) above the measured one; the measured number falls inside the stated range.
By their numbers in this assay, from the lowest: compound 3; then compounds 4, 2 and 1 (each within the scatter of the next, the first and the last beyond it).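

In this assay, replacing ethoxy with nitro gives a 3.9-fold higher number from compound 3 to compound 4 (0.60 log units; beyond the scatter), so ethoxy keeps its lead even over a group with the same count of 3 heavy atoms, and that count alone does not separate the two groups. Replacing ethyl with nitro gives a 3.5-fold lower number from compound 1 to compound 4 (0.54 log units; beyond the scatter), which shows that a group at this position can clearly improve on ethyl without matching ethoxy. Replacing fluoro with nitro gives a 1.9-fold lower number from compound 2 to compound 4 (0.28 log units; within the scatter), a step within the scatter, so nitro and fluoro cannot be told apart here, although they differ in their atoms.

Nothing available here explains why these groups rank as they do. Going by these compounds, it remains open whether the advantage of ethoxy is specific to that group or would extend to a methoxy, a longer chain such as propoxy, an amine or a carboxylic acid at the same place on the ring.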